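The source may hold more compounds than are shown below. What is called first, only, known or untested is meant among the compounds shown, and "the series" means these compounds.

Measured in a functional assay on J774 cells (Mus musculus) for cytotoxicity, read by resazurin assay; a lower number here means a stronger inhibitor, a higher number a weaker inhibitor:
Compound 1 `OCCCCCC(O)c1ccc(-c2ccc(F)cc2)cc1`: 18000 nM
Compound 2 `CCOc1ccc(-c2ccc(C(O)CCCCCO)cc2)cc1`: 14000 nM
Compound 3 `OCCCCCC(O)c1ccc(-c2ccc(F)cc2)cc1Cl`: 8000 nM

Compound 3 stands clearly under compound 1, while compound 2 and compound 3 lie within the scatter of each other. Compound 4 `OCCCCCC(O)c1ccc(-c2ccc(F)cc2)cc1F` differs from compound 3 by a single exchange, (fluoro in place of chloro on an aromatic carbon), fluoro in place of chloro on an aromatic carbon. The closest evidence is the modest 2.3-fold lower number from compound 1 to compound 3 (0.35 log units; beyond the scatter), where chloro replaced hydrogen on that same carbon. The a 1.3-fold lower number from compound 1 to compound 2 (0.11 log units; within the scatter) concerns a different aromatic carbon and stays within the scatter. Among the measured compounds shown here, no measured compound shows fluoro at this place, so only a small rise in this assay seems likely, possibly none beyond the scatter. The expected change is a 1.5-fold higher number from compound 3 to compound 4 (0.18 log units; within the scatter). For compound 4 the estimated value is 12000 nM, with an expected range of 6500 nM to 22000 nM.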

Compound 4, half-maximal inhibitory concentration: 14000 nM
Beside the measured number, compound 4's estimate is 1.2-fold (0.07 log units) below it; the measured number falls inside the stated range.
By their numbers in this assay, from the lowest: compounds 3, 2, 4 and 1 (each within the scatter of the next, the first and the last beyond it).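

At this aromatic carbon, exchanging chloro for fluoro gives no step beyond the scatter in this assay (a 1.8-fold higher number from compound 3 to compound 4 (0.24 log units; within the scatter)). Fluoro in place of hydrogen also stays within the scatter (a 1.3-fold lower number from compound 1 to compound 4 (0.11 log units; within the scatter)), so compound 4 cannot be separated from either neighbour, and only chloro is set apart from hydrogen here. Nothing measured here explains this result. Going by these compounds, whether a larger halogen such as bromo, or an amine, at this carbon would go further remains open. So does whether the chloro step would hold with the ethoxy of compound 2 on the other ring.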